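Trading an amide for a benzyl group on the shared core

The source may hold more compounds than are shown below. What is called first, only, known or untested is meant among the compounds shown, and "the series" means these compounds.

Compound 1 `CC(C)c1onc(-c2c(Cl)cccc2Cl)c1COc1ccc(N(C)C(=O)c2ccc(C(=O)O)cc2)c(C(F)(F)F)n1` is the starting point in a functional assay on HEK293 cells for agonist activity at Bile acid receptor (Homo sapiens); on this read-out higher numbers stand for an effect only at larger amounts of compound and lower numbers for an effect already at smaller amounts. In this assay compound 1 gives 316 nM. Compound 2 `Cc1cc(OCc2c(-c3c(Cl)cccc3Cl)noc2C(C)C)nc2ccccc12` gives 536 nM in this assay, and the two numbers lie within the scatter of each other, so no order between compound 1 and compound 2 can be read from them. Compound 3 `Cc1cc(C(F)(F)F)cc(OCc2c(-c3c(Cl)cccc3Cl)noc2C(C)C)n1` gives "not active" (no number reported) in this assay, with no number given. Compound 1 thus carries the lowest of the two numbers that were reported, but its gap to compound 2 says nothing beyond the scatter.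

Compound 4 `CC(C)c1onc(-c2c(Cl)cccc2Cl)c1COc1ccc(N(C)Cc2cccc(C(=O)O)c2)c(C(F)(F)F)n1` differs from compound 1 in a single place: 3-carboxybenzyl in place of (4-carboxyphenyl)carbonyl on a nitrogen on an aromatic ring. The carbonyl that linked the acid-bearing ring to that nitrogen in compound 1 is gone, and the carboxylic acid now sits on a 3-carboxybenzyl group instead of a (4-carboxyphenyl)carbonyl group. For the measured compounds named here, no pair of measured compounds shows this change, so the expectation rests on the change itself. The step of a 4.7-fold higher number from compound 1 to compound 4 (0.68 log units; beyond the scatter) is expected to go toward higher numbers and to exceed the scatter. Compound 4 is estimated at 1500 nM, with a range from 300 nM to 8000 nM, and a real chance that this assay reports only a limit for compound 4.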

Compound 4, half-maximal effective concentration: 80 nM
Compound 4: the middle estimate sits 19-fold (1.27 log units) above what was measured; the whole stated range lies above it.
By their numbers in this assay, from the lowest: compound 4; then compounds 1 and 2 (each within the scatter of the next).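

On the nitrogen on an aromatic ring, the carbonyl of compound 1 proves dispensable in this assay: replacing (4-carboxyphenyl)carbonyl with 3-carboxybenzyl gives a 4.0-fold lower number from compound 1 to compound 4 (0.60 log units; beyond the scatter), a modest step but one that clears the scatter. For the compounds shown here, this is the first change at this place whose effect can be read, since the earlier numbers offered no step between compounds differing in one place, and it shows that the group on this nitrogen can alter the read-out while the rest of the shared core stays fixed. Nothing available here explains the step, so it stands as an observation without a stated cause.

The single change removes the carbonyl and also replaces one carboxylic acid-bearing group with a differently named one, so the compounds shown cannot tell how much of the step belongs to each part of that swap. They also leave open whether the carboxylic acid itself is required, as a tetrazole or a primary amide in its place would test, and whether a longer chain between the nitrogen and the aromatic ring would be tolerated.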